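Swapping Trifluoromethyl for Ethyl on the Tetrazole Scaffold

This account rests on a few compounds, and the source may have more. Where it says the series, first, only, none or still open, it means among the compounds named here.

Measured compounds:
Compound 1, `CCc1cccc2cc(C(=O)O)cnc12`, gives 75 mg/kg in a functional assay on the whole organism (strain Sprague-Dawley) for inhibition, with Rattus norvegicus as the target; on this read-out lower numbers stand for an effect already at smaller amounts and higher numbers for an effect only at larger amounts of compound.
Compound 2, `FC(F)(F)c1cccc2cc(-c3nn[nH]n3)cnc12`, gives 25 mg/kg in this assay.

Of the two numbers recorded so far in this assay, compound 2 stands at the lower one; compound 1 gives the higher number, and the gap between the two lies beyond the usual scatter of this kind of measurement. The two compounds differ in more than one place, so no single step can be read from them.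

Compound 3, `CCc1cccc2cc(-c3nn[nH]n3)cnc12`, has not yet been measured. Relative to compound 2 the change is ethyl in place of trifluoromethyl on an aromatic carbon. Compound 1 carries the same ethyl group but with a different substituent on the other part of the core, so the data hold no direct measure of this change on its own. The account expects the step from compound 2 to compound 3 in this assay to be modest and towards a higher number, perhaps not clearly beyond the scatter, a 1.6-fold higher number from compound 2 to compound 3 (0.20 log units; within the scatter). Compound 3 is therefore estimated at 40 mg/kg in this assay, with a range of 15 mg/kg to 110 mg/kg.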

Compound 3, minimum effective dose: 5 mg/kg
Estimate against measurement, compound 3: 8.0-fold (0.90 log units) above; measured number outside the range, below it.
By their numbers in this assay, from the lowest: compound 3; then compound 2; then compound 1.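

In this assay, the aromatic carbon that holds trifluoromethyl in compound 2 proves sensitive to what sits on it: ethyl in place of trifluoromethyl gives a 5.0-fold lower number from compound 2 to compound 3 (0.70 log units; beyond the scatter), a change that compounds 1 and 2 alone could not isolate, since they differ in more than one place. With ethyl held constant, 2H-tetrazol-5-yl in place of carboxy on the other part of the core gives a 15-fold lower number from compound 1 to compound 3 (1.18 log units; beyond the scatter), so this exchange can now be read on its own as well, and it is a large step, while compound 3 stands apart from both other compounds by more than the scatter. Nothing at hand accounts for either step, so the numbers describe these two changes without explaining them.

On these data alone, whether a longer chain such as propyl, or a smaller group such as methyl, on this aromatic carbon would give a lower or a higher number than ethyl remains open. Also open, as far as these compounds go, is whether the ethyl and trifluoromethyl exchange would give a step of similar size with a carboxylic acid in place of the tetrazole, or whether an amide there would match either group.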